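A few compounds are considered here, and "the series" means these few. Any claim that something is new, unique, unknown or untested is made for them only; others in the source may bear on it.

Measured so far:
Compound 1, `COc1cc([C@](O)(CCN(C)C)[C@@H](c2cc3cc(C#N)ccc3nc2OC)c2cccc(C)c2F)cc(OC(F)F)n1`: 5.9 uL/min
Compound 2, `COc1nc2ccc(C#N)cc2cc1[C@@H](c1cccc(C)c1F)[C@@](O)(CCN(C)C)c1cc(SC)nc(SC)c1`: 13 uL/min
Compound 3, `CCSc1cc([C@](O)(CCN(C)C)[C@@H](c2cc3cc(C#N)ccc3nc2OC)c2cccc(OC)c2F)cc(SCC)n1`: 27 uL/min

All three numbers come from an ADME assay on microsomes from liver (Mus musculus) for metabolic stability; on this read-out higher numbers stand for fast clearance and lower numbers for slow clearance. Compound 3 stands at the top of this small set. Its gap from compound 2 lies beyond the usual scatter, and its gap from compound 1 is larger still. Whether that places compound 3 on the slow or the fast side of a broader series cannot be said from three compounds alone.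

Compound 4, `CCSc1cc([C@](O)(CCN(C)C)[C@@H](c2cc3cc(C#N)ccc3nc2OC)c2cccc(C)c2F)cc(SCC)n1`, differs from compound 3 in one spot only: methyl in place of methoxy on an aromatic carbon. Within the data shown here, no measured pair isolates this particular change. Among the measured compounds shown here, the only step that has been measured, a 2.2-fold higher number from compound 1 to compound 2 (0.34 log units; beyond the scatter), concerns a swap at a different place, on a saturated chain carbon rather than on the fluorinated aromatic ring, and so says nothing direct about exchanging a methoxy for a methyl. Without a matched pair to lean on, the expectation for compound 4 rests on the general observation that so small a change, one heavy atom traded for two, seldom shifts this read-out far. Compound 4 is therefore expected to sit close to compound 3, with a step of about a 1.4-fold lower number from compound 3 to compound 4 (0.13 log units; within the scatter), not beyond the scatter. The estimated value for compound 4 is 20 uL/min, within a range from 8 uL/min to 45 uL/min.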

Compound 4, intrinsic clearance in a liver preparation (reported as CLH), per the amount of preparation that the assay uses: 33 uL/min
Compound 4: middle estimate off by 1.7-fold (0.22 log units), on the low side; the range from low to high includes it.
By their numbers in this assay, from the lowest: compound 1; then compound 2; then compounds 3 and 4 (each within the scatter of the next).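

In this assay, among these compounds, trading methoxy for methyl on this aromatic carbon gives a 1.2-fold higher number from compound 3 to compound 4 (0.09 log units; within the scatter), the first direct reading at this position, and it shows that 2-fluoro-3-methoxyphenyl and 2-fluoro-3-methylphenyl cannot be told apart on this read-out when the rest of compound 3 stays the same. With the 2-fluoro-3-methylphenyl group shared, changing the group on the saturated chain carbon does move the number, giving a 2.5-fold higher number from compound 2 to compound 4 (0.40 log units; beyond the scatter) and a 5.6-fold higher number from compound 1 to compound 4 (0.75 log units; beyond the scatter), so among these compounds the steps beyond the scatter come from that other place. Nothing measured here bears on why any of these steps has its size.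

This position has been read only once, with the group of compound 3 and compound 4 on the saturated chain carbon, so the same swap could behave differently alongside the groups of compound 1 or compound 2. As far as these compounds go, it also remains open how this read-out would respond at the same aromatic carbon to a group of a different kind, such as an amine, a carboxylic acid or a longer chain like ethoxy.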